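Swapping the Aryl Group on a Carbamate Nitrogen

The source may hold more compounds than are shown below. What is called first, only, known or untested is meant among the compounds shown, and "the series" means these compounds.

Measured so far:
Compound 1, `COc1ccccc1NC(=O)Oc1cc(=O)n(CCCO)c2c1CC(CC=C(C)C)C(C)(C)C2`: 71.1%
Compound 2, `CC(C)=CCC1Cc2c(OC(=O)Nc3cccc(F)c3)cc(=O)n(CCCO)c2CC1(C)C`: 66.1%
Compound 3, `CC(C)=CCC1Cc2c(OC(=O)Nc3ccc(F)c(F)c3)cc(=O)n(CCCO)c2CC1(C)C`: 76.7%

These three compounds share one core and differ only in the aryl group carried on an amide-type nitrogen. In a functional assay on PANC-1 cells (Homo sapiens) for inhibition, read by MTT assay, with a stated time of 24 h, tested at 10 uM (on this read-out higher numbers stand for more inhibition at the one concentration tested (going by the name of the read-out) and lower numbers for less inhibition), compound 3 gives the highest of the three numbers, but its gap to compound 1 is within the scatter, so the two cannot be ranked; only compound 2 sits clearly lower, as the step of a number 10.6 percentage points higher from compound 2 to compound 3 (beyond the scatter) shows.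

Compound 4, `CC(C)=CCC1Cc2c(OC(=O)Nc3cccc(C(F)(F)F)c3)cc(=O)n(CCCO)c2CC1(C)C`, has not been measured. It differs from compound 3 in one place: 3-(trifluoromethyl)phenyl in place of 3,4-difluorophenyl on an amide-type nitrogen.

Among the measured compounds shown here, two measured steps touch this position. The step of a number 5.6 percentage points higher from compound 1 to compound 3 (within the scatter) is within the scatter, and the step of a number 10.6 percentage points higher from compound 2 to compound 3 (beyond the scatter) is modest. For the measured compounds named here, changing the aryl group has therefore moved the number only a little so far, and no measured step copies the present change exactly. A step within the scatter is expected here, in no clear direction, so compound 4 is expected to give 71%, between 58% and 84%, which means an expected step of a number 5.7 percentage points lower from compound 3 to compound 4 (within the scatter).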

Compound 4, a percentage reported as inhibition, at one concentration (the size of the read-out at that concentration, not a potency): 54.3%
The estimate for compound 4 lay 16.7 percentage points above the measured number, and the stated range ends above it.
By their numbers in this assay, from the lowest: compound 4; then compounds 2, 1 and 3 (each within the scatter of the next, the first and the last beyond it).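

Until now, changing the aryl group on this amide-type nitrogen had moved the number only a little, but 3-(trifluoromethyl)phenyl gives the largest fall yet seen at this position in this assay (a number 22.4 percentage points lower from compound 3 to compound 4 (beyond the scatter)). The fall is not limited to one comparison, since it also appears against the 3-fluorophenyl compound (a number 11.8 percentage points lower from compound 2 to compound 4 (beyond the scatter)) and the 2-methoxyphenyl compound (a number 16.8 percentage points lower from compound 1 to compound 4 (beyond the scatter)), so this position does not accept every aryl group equally. Nothing measured here explains why the number falls with this group.

With only four aryl groups shown, all but one of them carrying fluorine, it remains open how the number would respond to an amine or a carboxylic acid on the phenyl ring. A single concentration also gives the size of the effect, not a potency.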